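This account rests on a few compounds, and the source may have more. Where it says the series, first, only, none or still open, it means among the compounds named here.

Compound 1 (`COc1ncc(-c2ccc3c(c2)N(c2ccc(C)cc2)C(=O)CO3)cc1NS(=O)(=O)c1ccc(F)cc1`) gives 5870 nM in a functional assay on A549 cells (Homo sapiens) for antiproliferative activity, read by MTT assay, with a stated time of 72 h (a higher number here means a weaker inhibitor, a lower number a stronger inhibitor), and lies within the scatter of compound 2 (`COc1ncc(-c2ccc3c(c2)N(c2ccc(F)cc2)C(=O)CO3)cc1NS(=O)(=O)c1ccc(F)cc1`) at 6500 nM and of compound 3 (`COc1ncc(-c2ccc3c(c2)N(c2ccccc2)C(=O)CO3)cc1NS(=O)(=O)c1ccc(F)cc1`) at 3490 nM in the same read-out. Compound 4 (`Cc1ccc(N2C(=O)COc3ccc(-c4cnc(Cl)c(NS(=O)(=O)c5ccc(F)cc5)c4)cc32)cc1`) departs from compound 1 at another place, with chloro in place of methoxy on an aromatic carbon as the count of the change: chloro in place of methoxy on an aromatic carbon, next to the ring nitrogen and ortho to a ((4-fluorophenyl)sulfonyl)amino group. The measured steps are a 1.1-fold higher number from compound 1 to compound 2 (0.04 log units; within the scatter) and a 1.7-fold lower number from compound 1 to compound 3 (0.23 log units; within the scatter) and a 1.9-fold lower number from compound 2 to compound 3 (0.27 log units; within the scatter) and all three lie within the scatter. They exchange methyl, fluoro and hydrogen elsewhere in the molecule, so they do not bear directly on the methoxy group, which every measured compound carries. No step beyond the scatter can be derived from them, so none is expected in this assay for this change, though the uncertainty stays wide. The expected step is a 1.2-fold higher number from compound 1 to compound 4 (0.08 log units; within the scatter) on this estimate. Compound 4 is expected at 7000 nM on this estimate, with 2500 nM to 20000 nM as the estimated range.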

Compound 4, half-maximal inhibitory concentration: 30900 nM
Compound 4: middle estimate off by 4.4-fold (0.64 log units), on the low side; measured number above the stated range.
By their numbers in this assay, from the lowest: compounds 3, 1 and 2 (each within the scatter of the next); then compound 4.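

The position next to the ring nitrogen and ortho to a ((4-fluorophenyl)sulfonyl)amino group is the only place among the compounds shown where one exchange leaves the scatter in this assay: chloro in place of methoxy gives a 5.3-fold higher number from compound 1 to compound 4 (0.72 log units; beyond the scatter) and places compound 4 apart from compound 1, compound 2 and compound 3. The methyl, fluoro and hydrogen exchanges among those three all stayed within the scatter, so methoxy at this position matters more here than those groups do at theirs. No measurement here accounts for the step.

From the compounds shown here alone, this reading rests on a single pair, so it stays open whether an ethoxy or an amine at this position would stand nearer compound 1 or compound 4. Going by these compounds, whether the same exchange gives a similar step with fluoro or hydrogen in place of the methyl of compound 1 also stays open.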